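Piperidinyl Carbonyl Methyl in Place of Methoxycarbonyl Carbonyl

The source may hold more compounds than are shown below. What is called first, only, known or untested is meant among the compounds shown, and "the series" means these compounds.

Three measured compounds share one core and differ only in the group on an amine nitrogen. Compound 1 `N#CC1=C(NCC(=O)N2CCOCC2)N(c2ccccc2)C(=O)N2CCCCC(N3CCCC3)C12` carries a ((morpholin-4-yl)carbonyl)methyl group there and gives 73.5% in a functional assay on the whole organism (strain albino) for inhibition, with Rattus norvegicus as the target, read by paw edema, with stated times of 1 h and 3 h, at a dose of 20 mmol/kg by the intraperitoneal route; on this read-out higher numbers stand for a stronger effect at the one dose given and lower numbers for a weaker effect. Compound 2 `N#CC1=C(NCC(=O)N2CCCC2)N(c2ccccc2)C(=O)N2CCCCC(N3CCCC3)C12` carries the ((pyrrolidin-1-yl)carbonyl)methyl counterpart and gives 56% in this assay, the step being a number 17.5 percentage points lower from compound 1 to compound 2 (beyond the scatter). Compound 3 `COC(=O)C(=O)NC1=C(C#N)C2C(N3CCCC3)CCCCN2C(=O)N1c1ccccc1` bears a (methoxycarbonyl)carbonyl group and gives 88.3% in this assay, the highest of the three numbers, reached by a number 14.8 percentage points higher from compound 1 to compound 3 (beyond the scatter) and by a number 32.3 percentage points higher from compound 2 to compound 3 (beyond the scatter).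

Compound 4 `N#CC1=C(NCC(=O)N2CCCCC2)N(c2ccccc2)C(=O)N2CCCCC(N3CCCC3)C12` has not yet been measured. Its change from compound 3 is ((piperidin-1-yl)carbonyl)methyl in place of (methoxycarbonyl)carbonyl on an amine nitrogen. Going by the values given here, two measured steps bear on this change, and both run from a ring-bearing carbonyl methyl group to the (methoxycarbonyl)carbonyl group, one modest and one large, both upward. The step to compound 4 runs the opposite way, so a fall beyond the scatter is expected, on the order of a number 26.3 percentage points lower from compound 3 to compound 4 (beyond the scatter). Compound 1 and compound 2 give the two values that frame where such a ring-bearing group has landed so far. The value of compound 4 in this assay is therefore estimated at 62%, within a range from 45% to 78%.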

Compound 4, a percentage reported as inhibition, in the whole organism at one dose (the size of the read-out at that dose, not a potency): 53.5%
Compound 4: middle estimate off by 8.5 percentage points, on the high side; the range from low to high includes it.
By their numbers in this assay, from the lowest: compounds 4 and 2 (each within the scatter of the next); then compound 1; then compound 3.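

On the amine nitrogen, ((piperidin-1-yl)carbonyl)methyl in place of (methoxycarbonyl)carbonyl gives, in this assay, a number 34.8 percentage points lower from compound 3 to compound 4 (beyond the scatter), so all three ring-bearing carbonyl methyl groups shown now lie beyond the scatter below compound 3. Among those groups, the change on the carbonyl carbon from pyrrolidin-1-yl to piperidin-1-yl gives a number 2.5 percentage points lower from compound 2 to compound 4 (within the scatter), so this assay does not tell those two rings apart. The change from morpholin-4-yl to piperidin-1-yl instead gives a number 20 percentage points lower from compound 1 to compound 4 (beyond the scatter), which leaves morpholin-4-yl as the one ring of the three whose compound stands apart from both others, a distinction that compound 2 alone could only suggest.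

Nothing available explains these differences. The compounds shown leave open whether an open-chain amine such as dimethylamino on the same carbonyl carbon would stay with compound 2 and compound 4 or move toward compound 1, and whether the high value of compound 3 would survive an ethyl ester or a free carboxylic acid in place of its methyl ester.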